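This account rests on a few compounds, and the source may have more. Where it says the series, first, only, none or still open, it means among the compounds named here.

Measured compounds:
compound 1 `C/C(=C\CC/C(C)=C/CC[C@@H]1[C@@]2(C)CCC(=O)C(C)(C)[C@H]2CC[C@@]1(C)O)CC/C=C(\C)C(=O)OCc1cn(-c2cccc([N+](=O)[O-])c2)nn1`; in a functional assay on U-87MG ATCC cells for antiproliferative activity against U-87 MG (Homo sapiens), read by MTT assay, with a stated time of 48 h (on this read-out lower numbers stand for stronger inhibition and higher numbers for weaker inhibition), compound 1 gives 134000 nM.
compound 2 `C/C(=C\CC/C(C)=C/CC[C@@H]1[C@@]2(C)CCC(=O)C(C)(C)[C@H]2CC[C@@]1(C)O)CC/C=C(\C)C(=O)OCc1cn(-c2cccc(F)c2)nn1`; in this assay compound 2 gives only a limit, > 150000 nM.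

For the measured compounds named here, compound 1 holds the only numerical value shown; the one other value is a limit. The unmeasured compound 3 `C/C(=C\CC/C(C)=C/CC[C@@H]1[C@@]2(C)CCC(=O)C(C)(C)[C@H]2CC[C@@]1(C)O)CC/C=C(\C)C(=O)OCc1cn(-c2cccc(O)c2)nn1` differs from compound 1 by hydroxy in place of nitro on an aromatic carbon. Going by the values given here, the single measured step at that position, an at least 1.1-fold higher number from compound 1 to compound 2 (0.04 log units; that floor lies within the scatter), runs into the limit of > 150000 nM in this assay, at which 1 of the 2 values shown sits, and so gives a floor only, not the size of the change. No step with hydroxy is shown. Expected for compound 3 is a 1.2-fold higher number from compound 1 to compound 3 (0.08 log units; within the scatter), a small step in this assay with a fair chance that only a limit is reported. The estimate for compound 3 is 160000 nM, range 80000 nM to 400000 nM.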

Compound 3, half-maximal inhibitory concentration: > 150000 nM
Compound 3: no number, only a limit; the forecaster's own chance of this, stated with the estimate: 55%; the middle value lies beyond the limit too.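

In this assay, hydroxy in place of nitro gives an at least 1.1-fold higher number from compound 1 to compound 3 (0.04 log units; that floor lies within the scatter). Both replacements of nitro at this position shown so far now end in a limit rather than a number, so compound 1 remains the only compound with a measured value. The step between compound 2 and compound 3 cannot be read, and the limit now holds most of the series: the limit of > 150000 nM in this assay, at which 2 of the 3 values shown sit.

From the compounds shown here alone, how far compound 2 and compound 3 lie beyond the limit stays open. Also open, going by these compounds, is whether an amine or a carboxylic acid at this position would give a number within the measurable range.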